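Five-membered ring swap: compound 2 to compound 3

The compounds below may be only part of what the source reports. "The series", "measured", "known", "first", "only" and "open" are said of these compounds alone.

Measured so far:
compound 1 `Cc1cccc(-c2ccccc2OCC2=NCCN2)n1`: 80%
compound 2 `c1coc(-c2ccccc2OCC2=NCCN2)c1`: 106%

In a functional assay with Alpha-1A adrenergic receptor (Homo sapiens) as the target, read by calcium flux (on this read-out higher numbers stand for larger maximal responses and lower numbers for smaller maximal responses), compound 1 gives 80%, while compound 2 gives 106%. Compound 2 stands highest of the two numbers; its gap to compound 1 lies beyond the scatter. Compound 3 `c1ccc(-c2ccsc2)c(OCC2=NCCN2)c1` is not yet measured. It differs from compound 2 in one place: thiophen-3-yl in place of furan-2-yl on an aromatic carbon. Among the compounds with values here, no step between measured compounds covers this change, so no direct guide exists. The expected step of a number 9 percentage points lower from compound 2 to compound 3 (within the scatter) is small, at most within the scatter, in this assay. Compound 3 is estimated at 97%, with a range from 78% to 116%.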

Compound 3, largest response reached (reported as maximum), in percent of the reference or control that the assay uses: 98%
Compound 3: middle estimate off by 1 percentage points, on the low side; the range from low to high includes it.
By their numbers in this assay, from the lowest: compound 1; then compounds 3 and 2 (each within the scatter of the next).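

In this assay, thiophen-3-yl in place of furan-2-yl on an aromatic carbon gives a number 8 percentage points lower from compound 2 to compound 3 (within the scatter) and so the read-out does not separate these two five-membered aromatic rings at this position. The change replaces oxygen with sulfur and also moves the point of attachment, so this single step cannot be assigned to either difference. Nothing available bears on the reason for the step.

Open, on these data alone, is how thiophen-2-yl or furan-3-yl would read here, since each would separate those two differences. Also open, as far as these compounds go, is whether an amine or a carboxylic acid on the five-membered ring would keep the maximal response.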